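This account rests on a few compounds, and the source may have more. Where it says the series, first, only, none or still open, it means among the compounds named here.

Notes on the series. In a functional assay on HCT-116 cells (Homo sapiens) for cytotoxicity, read by MTT assay, with a stated time of 72 h (a lower number here means a stronger inhibitor, a higher number a weaker inhibitor), compound 1 `C=C1C2=C(C(=O)N1OC)[C@H](OC(=O)CSc1nc3ccccc3o1)[C@@](C)(O)[C@H](CCCCC)O2` gives 4900 nM and compound 2 `C=C1C2=C(C(=O)N1OC)[C@H](OC(=O)CSc1nc3ccccc3s1)[C@@](C)(O)[C@H](CCCCC)O2` gives 4700 nM, so compound 2 stands level with compound 1 within the scatter. The next comparison is compound 3 `C=C1C2=C(C(=O)N1OC)[C@H](OC(=O)CCCCCl)[C@@](C)(O)[C@H](CCCCC)O2`, in which 3-chloropropyl takes the place of (1,3-benzothiazol-2-yl)sulfanyl on a saturated chain carbon bound to a carbonyl carbon: 3-chloropropyl in place of (1,3-benzothiazol-2-yl)sulfanyl on a saturated chain carbon bound to a carbonyl carbon.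

Among the measured compounds shown here, only one measured step bears on this change: a 1.0-fold lower number from compound 1 to compound 2 (0.02 log units; within the scatter), with 1,3-benzothiazol-2-yl in place of 1,3-benzoxazol-2-yl on a sulfur. That step keeps the sulfur and exchanges one ring-bearing group for another, whereas the change to compound 3 removes the sulfur and both aromatic rings. For the measured compounds named here, its small size therefore gives only weak guidance, and no measured compound in this assay lacks those rings. A modest move towards a higher number is expected, though with little support from the data, and the range is kept wide. The expected step is a 1.5-fold higher number from compound 2 to compound 3 (0.17 log units; within the scatter). For compound 3 the estimated value is 7000 nM, with an expected range of 2500 nM to 20000 nM.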

Compound 3, half-maximal inhibitory concentration: 11000 nM
The estimate for compound 3 lay 1.6-fold (0.20 log units) below the measured number; the range from low to high includes it.
By their numbers in this assay, from the lowest: compounds 2 and 1 (each within the scatter of the next); then compound 3.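

Exchanging (1,3-benzothiazol-2-yl)sulfanyl for 3-chloropropyl on a saturated chain carbon bound to a carbonyl carbon gives a 2.3-fold higher number from compound 2 to compound 3 (0.37 log units; beyond the scatter) in this assay and the matching exchange from (1,3-benzoxazol-2-yl)sulfanyl gives a 2.2-fold higher number from compound 1 to compound 3 (0.35 log units; beyond the scatter) in the same read-out. This position therefore responds to a change of the whole group, a response that the earlier exchange between the two ring-bearing groups did not show, yet the modest size of both steps means that the sulfur and both aromatic rings are not needed for a measurable number in this assay. No measurement shown here accounts for the move to the higher number.

Among the compounds shown here, the single step changes several things at once, so the shares of the lost sulfur, the lost aromatic rings and the entering chlorine stay unresolved, and a plain butyl chain or a 4-chlorobutyl group's sulfur-linked counterpart would begin to separate them. Also open, as far as these compounds go, is how this position responds to an amine or a carboxylic acid at the end of the chain, or to a longer chain.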